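This account rests on a few compounds, and the source may have more. Where it says the series, first, only, none or still open, it means among the compounds named here.

Measured so far in an assay on isolated protein for inhibition of Rho-associated protein kinase 1 (Homo sapiens), read by scintillation counting, radiometric assay and 33P incorporation, with a stated time of 40 min, in the presence of a further agent that is not named here; on this read-out lower numbers stand for stronger inhibition and higher numbers for weaker inhibition:

- Compound 1, `CN(C)c1ccc(C(=O)Nc2cccc(NC(=O)COc3ccc4c(c3)NC(=O)CC4)c2)cc1`: compound 1 sits at the limit of this assay, > 10000 nM.
- Compound 2, `CN(C)c1ccc(C(=O)Nc2cccc(NC(=O)COc3ccc4c(c3)OCCO4)c2)cc1`: compound 2 likewise sits at the limit, > 10000 nM.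
- Compound 3, `CC(C)(C)c1ccc(C(=O)Nc2cccc(NC(=O)COc3ccc4c(=O)ccoc4c3)c2)cc1`: compound 3 gives 165 nM.

Going by the values given here, compound 3 carries the only number in the set; the other two values are limits of this assay, as the limit of > 10000 nM in this assay, at which 2 of the 3 values shown sit, records. Among the compounds with values here, the one step that can be computed, a step that the two limits leave unreadable from compound 1 to compound 2, runs between two limits and its size cannot be read. It also touches a different place of the shared core, on an oxygen on a saturated carbon, and so says nothing about the change now in view.

Compound 4, `Cc1cc(C(=O)Nc2cccc(NC(=O)COc3ccc4c(=O)ccoc4c3)c2)no1`, differs from compound 3 only at the carbonyl carbon whose other neighbour is the amide-type nitrogen: 5-methyl-1,2-oxazol-3-yl in place of 4-(tert-butyl)phenyl on a carbonyl carbon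

Within the data shown here, no measured step bears on this exchange. The expectation therefore rests on compound 3 alone, with the change left open in direction; a step of a 2.4-fold higher number from compound 3 to compound 4 (0.38 log units; beyond the scatter) is expected, within or near the scatter of this assay. Compound 4 is estimated at 400 nM, with a range from 100 nM to 3000 nM.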

Compound 4, half-maximal inhibitory concentration: 68 nM
For compound 4 the middle estimate is 5.9-fold (0.77 log units) above the measured one; measured number outside the range, below it.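

Putting 5-methyl-1,2-oxazol-3-yl in place of 4-(tert-butyl)phenyl on a carbonyl carbon gives a 2.4-fold lower number from compound 3 to compound 4 (0.38 log units; beyond the scatter) in this assay, so inhibition at this place does not depend on a six-membered aromatic ring of carbon only. The group that enters has fewer heavy atoms than the group that leaves and carries hydrogen-bond acceptors where the group that leaves has none, and in this pair neither the larger group nor the all-carbon ring is needed for the lower number. Going by these compounds alone, nothing measured so far ties the step to any one of these differences between the two groups.

With a single pair at this place, the contributions of the ring hetero atoms, the methyl group and the loss of the tert-butyl group stay unseparated, and an unsubstituted phenyl, a 1,2-oxazol-3-yl without the methyl or a pyridyl ring would be needed to pull them apart. From the compounds shown here alone, compounds 1 and 2 stand only as limits and differ from compound 3 in more than one place, so whether the exchange holds with other groups elsewhere on the shared core remains open.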